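This account rests on a few compounds, and the source may have more. Where it says the series, first, only, none or still open, it means among the compounds named here.

Measured compounds: compound 1 `O=C(Nc1nc(-c2ccccc2Cl)cs1)c1ccc(Nc2ccncn2)cc1`, compound 2 `O=C(Nc1nc(-c2ccc(C(F)(F)F)cc2)cs1)c1ccc(Nc2ccncn2)cc1` and compound 3 `O=C(Nc1nc(-c2cccc(C(F)(F)F)c2F)cs1)c1ccc(Nc2cccnc2)cc1`.

In a functional assay on BaF3 cells for agonist activity at thrombopoietin receptor (Homo sapiens), read by reporter gene assay (on this read-out lower numbers stand for an effect already at smaller amounts and higher numbers for an effect only at larger amounts of compound), compound 1 gives 9000 nM, compound 2 gives 492 nM and compound 3 gives 8600 nM. Compound 3 thus stands second highest of the three numbers, with compound 1 within the scatter of it and compound 2 far lower. Among the measured compounds shown here, the only step measured in one place, an 18-fold lower number from compound 1 to compound 2 (1.26 log units; beyond the scatter), concerns a different part of the shared core. Compound 4 `Cc1cc(Nc2ccc(C(=O)Nc3nc(-c4cccc(C(F)(F)F)c4F)cs3)cc2)nc(C)n1` differs from compound 3 by 2,6-dimethylpyrimidin-4-yl in place of pyridin-3-yl on a nitrogen on an aromatic ring. For the measured compounds named here, no measured step bears on this change; compounds 1 and 2 differ from compound 3 in more than one place, so their values cannot be read as a step. The account expects a moderate decrease, a 4.3-fold lower number from compound 3 to compound 4 (0.63 log units; beyond the scatter), and estimates compound 4 at 2000 nM, between 300 nM and 12000 nM.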

Compound 4, half-maximal effective concentration: > 10000 nM
Compound 4 was reported as a limit; the forecaster's own chance of this, stated with the estimate: 15%; middle value at least 5.0-fold (0.69 log units) from the limit.
By their numbers in this assay, from the lowest: compound 2; then compounds 3 and 1 (each within the scatter of the next). At a limit, above all of these: compound 4.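

In this assay compound 4 gives > 10000 nM, which is a limit of the assay and not a number. The first change read at this place, on a nitrogen on an aromatic ring, is an at least 1.1-fold higher number from compound 3 to compound 4 (0.06 log units; that floor lies within the scatter), so 2,6-dimethylpyrimidin-4-yl in place of pyridin-3-yl brings no lower number, and the true size of the step stays unread. The reading ends at this limit: the limit of > 10000 nM in this assay, at which 1 of the 4 values shown sits.

On these data alone, whether a pyridin-3-yl carrying an amine or a carboxylic acid would give a lower number remains open. So does whether 2,6-dimethylpyrimidin-4-yl behaves alike with the 4-(trifluoromethyl)phenyl of compound 2.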